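The source may hold more compounds than are shown below. What is called first, only, known or untested is meant among the compounds shown, and "the series" means these compounds.

In a functional assay on Shh Light II cells (Mus musculus) for inhibition, read by a luciferase reporter (a lower number here means a stronger inhibitor, a higher number a weaker inhibitor), three compounds built on one shared core have been measured so far. Compound 1 `O=C(Nc1ccccc1Cl)N1CCC(c2nc(-c3ccc4ccccc4n3)no2)CC1` gives 510 nM, compound 2 `O=C(NC1CCS(=O)(=O)CC1)N1CCC(c2nc(-c3ccc4ccccc4n3)no2)CC1` gives 360 nM, and compound 3 `COc1ccccc1N(C)C(=O)N1CCC(c2nc(-c3ccc4ccccc4n3)no2)CC1` gives 3100 nM. Compound 3 thus stands at the highest number of the three: a 6.1-fold higher number from compound 1 to compound 3 (0.78 log units; beyond the scatter) and an 8.6-fold higher number from compound 2 to compound 3 (0.94 log units; beyond the scatter), whereas the first two compounds lie close to one another, as a 1.4-fold lower number from compound 1 to compound 2 (0.15 log units; within the scatter) shows.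

Compound 4 `Cc1ccccc1NC(=O)N1CCC(c2nc(-c3ccc4ccccc4n3)no2)CC1` differs from compound 3 in one place only, on the carbonyl carbon: (2-methylphenyl)amino in place of (2-methoxyphenyl)(methyl)amino on a carbonyl carbon. The group that enters carries one hydrogen-bond donor, as the groups on that carbonyl carbon in compound 1 and compound 2 do, and the group that leaves is the very one whose arrival from compound 1 brought a 6.1-fold higher number from compound 1 to compound 3 (0.78 log units; beyond the scatter). Both measured steps into compound 3 were modest rises that lay beyond the scatter, so the step back out of it is expected to be a fall of comparable size in this assay; the estimated change is a 5.6-fold lower number from compound 3 to compound 4 (0.75 log units; beyond the scatter). Compound 4 is therefore expected to give about 550 nM, with a likely range from 200 nM to 1500 nM.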

Compound 4, half-maximal inhibitory concentration: 440 nM
Estimate against measurement, compound 4: 1.3-fold (0.10 log units) above, within the range that was stated.
By their numbers in this assay, from the lowest: compounds 2, 4 and 1 (each within the scatter of the next); then compound 3.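

In this assay, the step with (2-methylphenyl)amino in place of (2-methoxyphenyl)(methyl)amino on the carbonyl carbon is a 7.0-fold lower number from compound 3 to compound 4 (0.85 log units; beyond the scatter), so a second aromatic group carrying one hydrogen-bond donor at this place joins compound 1 and compound 2, leaving compound 3, the only one of the four with no donor in this group, apart from the rest. Two further comparisons show how little separates the three donor compounds: methyl in place of chloro on the aromatic carbon gives a 1.2-fold lower number from compound 1 to compound 4 (0.06 log units; within the scatter), and 2-methylphenyl in place of 1,1-dioxothian-4-yl on the amide-type nitrogen gives a 1.2-fold higher number from compound 2 to compound 4 (0.09 log units; within the scatter), both within the scatter. The data on hand offer no measured explanation for this pattern.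

Compound 3 and compound 4 differ both in the methyl on the nitrogen and in the group on the aromatic ring, so these two changes cannot yet be told apart. A (2-methoxyphenyl)amino group would separate them, while an (N-methyl)(2-methylphenyl)amino group would test the methyl on the nitrogen from the other side.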